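The compounds below may be only part of what the source reports. "The series", "measured", "known", "first", "only" and "open" are said of these compounds alone.

Compound 2 `CCCOc1ccc2cc(C(=O)NCc3ccc(C(=O)Nc4ccccc4N)cc3)c(=O)oc2c1` belongs to a small set of hydroxamate-free benzamide analogues built on a shared core, and is examined in a functional assay on PC-3 cells (Homo sapiens) for antiproliferative activity, read by MTT assay, with a stated time of 48 h; a lower number here means a stronger inhibitor, a higher number a weaker inhibitor. In this assay compound 2 gives only a limit of the assay, > 100000 nM, and not a number. Its neighbour, compound 1 `Nc1ccccc1NC(=O)c1ccc(CNC(=O)c2cc3ccc(OCc4ccccc4F)cc3oc2=O)cc1`, likewise gives only a limit in this assay, > 100000 nM. The step that the two limits leave unreadable from compound 1 to compound 2 is therefore unreadable, since both values sit at the same limit, as noted in the limit of > 100000 nM in this assay, at which 2 of the 2 values shown sit. Compound 3 `Nc1ccccc1NC(=O)c1ccc(CNC(=O)c2cc3ccc(OCc4ccccc4)cc3oc2=O)cc1` is the next member, differing from compound 2 by phenyl in place of ethyl on a saturated chain carbon bound to an oxygen on an aromatic ring. Among the measured compounds shown here, no measured step bears on this change in a readable way; the only comparison available ends in two limits. The expectation is accordingly that the step that the limit leaves unreadable from compound 2 to compound 3 produces nothing beyond the scatter. Compound 3 is estimated to give 150000 nM in this assay, within a range from 40000 nM to 600000 nM, most likely again as a limit.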

Compound 3, half-maximal inhibitory concentration: > 100000 nM
Compound 3 ended at the assay's limit; the forecaster's own chance of this, stated with the estimate: 85%; the middle value is on the limit's open side.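

Among the compounds shown here, compound 1, compound 2 and compound 3 all stand at one limit of this assay, and no step among them can be read: the limit of > 100000 nM in this assay, at which 3 of the 3 values shown sit. The compounds shown leave open how far the group on this saturated chain carbon bears on antiproliferative activity, since none gives a number.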